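A few compounds are considered here, and "the series" means these few. Any claim that something is new, unique, unknown or untested is made for them only; others in the source may bear on it.

Measured compounds and their values:
- compound 1, `CC(C)(C)OC(=O)c1cccc(NC(=O)C2CCCN(C(=O)c3cc(C(F)(F)F)cc(C(F)(F)F)c3)C2)c1`: 0%
- compound 2, `CC(C)(C)CC(=O)Nc1cccc(C(=O)N2CCCC(C(=O)Nc3ccc(Cl)cc3)C2)c1`: 0%
- compound 3, `O=C(Nc1ccc(Cl)cc1)C1CCCN(C(=O)c2cccc(-c3cccs3)c2)C1`: 4%

In an ADME assay on PC-3 cells (Homo sapiens) for cytotoxicity, read by WST assay, tested at 100 uM (on this read-out higher numbers stand for more inhibition at the one concentration tested (going by the name of the read-out) and lower numbers for less inhibition), compound 1 stands level with compound 2 at the digits shown, the two together the lowest of the three numbers, while compound 3 sits only slightly apart, within the scatter. The step now followed leads to compound 4, `O=C(c1ccccc1)c1cccc(NC(=O)C2CCCN(C(=O)c3cc(C(F)(F)F)cc(C(F)(F)F)c3)C2)c1`, which differs from compound 1 in one place: phenyl in place of tert-butoxy on a carbonyl carbon. Among the compounds with values here, none of the measured steps touches this change; the one step recorded, a number 4 percentage points higher from compound 2 to compound 3 (within the scatter), concerns a different position and stayed within the scatter. With nothing pointing to a shift in either direction, compound 4 is expected to remain at the bottom of the range, with a number 2 percentage points higher from compound 1 to compound 4 (within the scatter) as the estimated step. The estimate for compound 4 is 2%, expected between 0% and 10%.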

Compound 4, a percentage reported as inhibition, at one concentration (the size of the read-out at that concentration, not a potency): 0%
Compound 4: middle estimate off by 2 percentage points, on the high side; the range from low to high includes it.
By their numbers in this assay, from the lowest: compounds 1, 2, 4 and 3 (each within the scatter of the next).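

In this assay, putting phenyl in place of tert-butoxy on this carbonyl carbon, which turns tert-butoxycarbonyl into benzoyl, gives no change at the digits printed from compound 1 to compound 4 (within the scatter). This is the first step shown at this position, and it shows that an aromatic ring of carbon only can replace a branched group bearing oxygen without moving the number. Nothing measured here offers an explanation for this result.

Going by these compounds, whether an amine or a longer chain on this carbonyl carbon would give a higher number remains open.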